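A few compounds are considered here, and "the series" means these few. Any claim that something is new, unique, unknown or untested is made for them only; others in the source may bear on it.

- compound 1 `Cc1ccc2[nH]c(-n3cccn3)c(C3=C(Br)C(=O)NC3=O)c2c1` with 8000 nM
- compound 2 `Cc1ccc2[nH]c3c4cn[nH]c4c4c(c3c2c1)C(=O)NC4=O` with 2000 nM

Going by the values given here, in a functional assay on B16-F10 cells (Mus musculus) for cytotoxicity, read by MTT assay, with a stated time of 72 h (a lower number here means a stronger inhibitor, a higher number a weaker inhibitor), compound 1 gives 8000 nM as the higher of the two numbers measured so far, which makes it the weaker inhibitor of the pair. Compound 2 stands lower at 2000 nM and the gap between them lies beyond the usual scatter.

Compound 3 `O=C1NC(=O)C(c2c(-n3cccn3)[nH]c3ccccc23)=C1Br` has not yet been measured. It departs from compound 1 in a single place (hydrogen in place of methyl on an aromatic carbon), with hydrogen in place of methyl on an aromatic carbon. Among the compounds with values here, no pair of measured compounds differs in one place only, so the data offer no direct precedent for this change.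

In this assay no step beyond the scatter is expected, and neither direction is favoured. This expectation rests only on the small size of the change and on compound 1 at 8000 nM as the starting point. The expected result is (a 1.1-fold lower number from compound 1 to compound 3 (0.06 log units; within the scatter)) a small move at most. For compound 3 the estimated value is 7000 nM with an expected range from 2500 nM to 20000 nM in this measurement.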

Compound 3, half-maximal inhibitory concentration: 13000 nM
Compound 3: middle estimate off by 1.9-fold (0.27 log units), on the low side; the measured number falls inside the stated range.
By their numbers in this assay, from the lowest: compound 2; then compounds 1 and 3 (each within the scatter of the next).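

In this assay, going by these compounds alone, placing hydrogen where compound 1 carries a methyl on the aromatic carbon gives a 1.6-fold higher number from compound 1 to compound 3 (0.21 log units; within the scatter), and this is the first comparison in which only one place differs. At this carbon of the six-membered aromatic ring, the methyl and the hydrogen therefore cannot be told apart in this read-out, so on the core of compound 1 the methyl is not required for the cytotoxicity seen at this level. No measurement is available that would account for this step or give a reason for its size.

Only methyl and hydrogen are shown at this carbon, so it remains open whether a methoxy group, a chlorine atom, an amine, a carboxylic acid or a longer chain there would give a step beyond the scatter. From the compounds shown here alone, it also remains open whether the same tolerance would hold on a different core, since compound 2 differs from compound 1 and compound 3 in more than one place and offers no comparison for this change.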